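From Dichlorophenyl to Dihydroxyphenyl on a Shared Core

The compounds below may be only part of what the source reports. "The series", "measured", "known", "first", "only" and "open" are said of these compounds alone.

- compound 1 `COc1ccc(/C=C2\CCC/C(=C\c3cccc(O)c3)C2=O)cc1OC`: 4300 nM
- compound 2 `COc1ccc(/C=C2\CCC/C(=C\c3ccc(Cl)c(Cl)c3)C2=O)cc1OC`: 6900 nM

In a functional assay on A549 cells (Homo sapiens) for cytotoxicity, read by MTT assay, with a stated time of 72 h (on this read-out higher numbers stand for weaker inhibition and lower numbers for stronger inhibition), compound 2 gives 6900 nM, and compound 1 lies within the scatter of it at 4300 nM. Compound 3 `COc1ccc(/C=C2\CCC/C(=C\c3ccc(O)c(O)c3)C2=O)cc1OC` differs from compound 2 by 3,4-dihydroxyphenyl in place of 3,4-dichlorophenyl on a double-bonded chain carbon bound to a double-bonded ring carbon. Going by the values given here, the only measured step at this place, a 1.6-fold higher number from compound 1 to compound 2 (0.21 log units; within the scatter), bears on the change, so no step beyond the scatter is expected in this assay. The expected step is a 1.7-fold lower number from compound 2 to compound 3 (0.24 log units; within the scatter). The estimate for compound 3 is 4000 nM, with an estimated range of 1500 nM to 10000 nM.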

Compound 3, half-maximal inhibitory concentration: > 20000 nM
Compound 3: a limit, no number; the forecaster's own chance of this, stated with the estimate: 2%; middle value at least 5.0-fold (0.69 log units) away from the limit.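

The value of compound 3 in this assay is a limit of the assay and not a number: the limit of > 20000 nM in this assay, at which 1 of the 3 values shown sits. Compounds 1 and 2 lay within the scatter of each other, yet this position does respond to substitution, with an at least 2.8-fold higher number from compound 2 to compound 3 (0.46 log units; beyond the scatter). A single hydroxy in place of hydrogen on an aromatic carbon is enough to give an at least 4.6-fold higher number from compound 1 to compound 3 (0.66 log units; beyond the scatter).

From the compounds shown here alone, the full size of both steps stays open. So does whether a 3,4-dimethoxyphenyl or a 3-aminophenyl group here would behave like 3,4-dihydroxyphenyl or like 3,4-dichlorophenyl.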